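The compounds below may be only part of what the source reports. "The series", "measured", "known", "first", "only" and "open" are said of these compounds alone.

Measured so far, in an assay on mitochondria from brain for inhibition of Amine oxidase [flavin-containing] B (Bos taurus); on this read-out higher numbers stand for weaker inhibition and lower numbers for stronger inhibition:
Compound 1, `CCOC(=O)c1ccc(NC(=O)C(=O)c2ccccc2NC(C)=O)cc1`, gives 990000 nM.
Compound 2, `COC(=O)[C@H](CC(C)C)NC(=O)C(=O)c1ccccc1NC(C)=O`, gives 480000 nM.

Compound 2 holds the lower of the two numbers; its gap to compound 1 lies beyond the usual scatter, so compound 2 is the stronger inhibitor of the pair. Compound 3, `COC(=O)C[C@H](NC(=O)C(=O)c1ccccc1NC(C)=O)C(=O)OC`, has not yet been measured. It differs from compound 2 in one place: methoxycarbonyl in place of isopropyl on a saturated chain carbon, two bonds along the chain from an amide-type nitrogen and a carbonyl carbon. For the measured compounds named here, no measured pair shows this change, so the size of the step is open. Both known numbers are high, and only a small step, or none beyond the scatter, is expected. For compound 3 the estimate in this assay is 650000 nM, expected to fall within 180000 nM to 2000000 nM. The expected step, a 1.4-fold higher number from compound 2 to compound 3 (0.13 log units; within the scatter), is a modest weakening.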

Compound 3, half-maximal inhibitory concentration: 460000 nM
Estimate against measurement, compound 3: 1.4-fold (0.15 log units) above; the range from low to high includes it.
By their numbers in this assay, from the lowest: compounds 3 and 2 (each within the scatter of the next); then compound 1.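

On this saturated chain carbon, two bonds along the chain from an amide-type nitrogen and a carbonyl carbon, methoxycarbonyl can stand in place of isopropyl with no change that can be told apart in this assay: the step is a 1.0-fold lower number from compound 2 to compound 3 (0.02 log units; within the scatter). The swap brings in two hydrogen-bond acceptors where isopropyl has none, yet the two numbers stay within the scatter of each other. No measurement here explains why the two groups read alike.

Going by these compounds, whether a carboxylic acid, an amine or a longer chain on this carbon would shift the number remains open.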